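The source may report more compounds than this note shows. Statements on the series, on what has been measured and on what is new or still open speak of the compounds shown alone.

Three measured compounds share one core. Compound 1 `COc1ccc(-c2cc(/C=C/C(=O)c3cc(OC)c(OC)c(OC)c3)nc3cc(-c4ccccc4)nn23)cc1OC` gives 35000 nM in an ADME assay on HEK293 cells (Homo sapiens) for antiproliferative activity, read by MTT assay, with a stated time of 24 h (a lower number here means a stronger inhibitor, a higher number a weaker inhibitor), the lowest of the three numbers. Compound 2 `COc1cc(-c2cc(C(=O)/C=C/c3ccccc3)nc3cc(-c4ccccc4)nn23)cc(OC)c1OC` gives 44800 nM and compound 3 `COc1ccc(-c2cc(/C=C/C(=O)c3ccc(OC)c(OC)c3)nc3cc(-c4ccccc4)nn23)cc1` gives 48500 nM; both sit within the scatter of compound 1, so no order among the three can be read from these values. Compound 3 already carries fewer methoxy groups than compound 1 on the ring attached to the carbonyl, and its value is indistinguishable from that of compound 1.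

Compound 4 `COc1ccc(-c2cc(/C=C/C(=O)c3ccccc3)nc3cc(-c4ccccc4)nn23)cc1OC` is not yet measured. It differs from compound 1 in one place: phenyl in place of 3,4,5-trimethoxyphenyl on a carbonyl carbon. Among the compounds with values here, no step between measured compounds matches this change. Given that the three measured values all fall within the scatter of one another, the step of a 1.4-fold higher number from compound 1 to compound 4 (0.14 log units; within the scatter) is expected to be small, leaning toward a slightly higher number if anything, and likely not beyond the scatter. The expected value for compound 4 is 48000 nM, with a range from 20000 nM to 120000 nM.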

Compound 4, half-maximal inhibitory concentration: 51200 nM
Compound 4: the middle estimate sits 1.1-fold (0.03 log units) below what was measured, and the stated range covers the measured number.
By their numbers in this assay, from the lowest: compounds 1, 2, 3 and 4 (each within the scatter of the next).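

Phenyl in place of 3,4,5-trimethoxyphenyl on a carbonyl carbon is the only one-place step in the series, and in this assay it gives a 1.5-fold higher number from compound 1 to compound 4 (0.17 log units; within the scatter) with the other substituents held constant. Within the data shown here, the earlier compounds differed in more than one place, so only this pair isolates the change at this position, and removing all three methoxy groups from this ring leaves the value within the scatter. No measurement available here bears on the reason for the size of this step.

Going by these compounds, whether any other group on this carbonyl carbon can give a step beyond the scatter remains open, for example a piperidine amine or a benzoic acid ring carrying a carboxylic acid. On these data alone, whether the same change stays this small with other groups elsewhere on the shared core is also open.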